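This account rests on a few compounds, and the source may have more. Where it says the series, first, only, none or still open, it means among the compounds named here.

Three compounds have numbers in a functional assay on the whole organism for inhibition, with Rattus norvegicus as the target, with stated times of 1 h and 3.5 h, at a dose of 100 mg/kg by the oral route; a lower number here means less inhibition, a higher number more inhibition at the dose given (going by the name of the read-out):
compound 1 `CC(C)(C)c1nc(N)ncc1-c1ccccc1` gives 46%;
compound 2 `CC(C)(C)c1nc(N)ncc1-c1cccc(C(F)(F)F)c1` gives 8%;
compound 3 `CC(C)(C)Nc1nccc(C(C)(C)C)n1` gives 26%.

Compound 3 stands second highest of these three numbers. Its nearest neighbour is compound 2, whose number lies lower by a gap beyond the scatter, and the furthest is compound 1, whose number lies higher, again by a gap beyond the scatter.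

Only one measured step joins two of these compounds in one place: a number 38 percentage points lower from compound 1 to compound 2 (beyond the scatter), trifluoromethyl in place of hydrogen on an aromatic carbon. That change concerns a group and a site that compound 3 does not carry, so it does not speak to the step now in question.

Compound 4 `CSc1nccc(C(C)(C)C)n1` differs from compound 3 in one place: methylsulfanyl in place of (tert-butyl)amino on an aromatic carbon. For the measured compounds named here, no measured pair shows what happens when (tert-butyl)amino gives way to methylsulfanyl, so the direction of the step rests on no observed precedent. In the absence of such a precedent, the expected step in this assay is a number 6 percentage points lower from compound 3 to compound 4 (within the scatter), a step not expected to exceed the scatter. Compound 4 is therefore estimated to give 20% in this assay, with a range from 0% to 45%.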

Compound 4, a percentage reported as inhibition, in the whole organism at one dose (the size of the read-out at that dose, not a potency): 35%
Beside the measured number, compound 4's estimate is 15 percentage points below it; the measured number falls inside the stated range.
By their numbers in this assay, from the lowest: compound 2; then compounds 3 and 4 (each within the scatter of the next); then compound 1.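

In this assay, the first step read at this position, on an aromatic carbon between two ring nitrogen atoms, is a number 9 percentage points higher from compound 3 to compound 4 (within the scatter). The group shrinks from 5 heavy atoms in (tert-butyl)amino to 2 in methylsulfanyl, and its hydrogen-bond donor count falls from 1 to 0, yet this single pair shows no change in the read-out beyond the scatter, so neither the bulk of (tert-butyl)amino nor its donor is shown to be required for the inhibition seen at this dose. The data offer no measurement that would explain this outcome.

As far as these compounds go, it remains open whether methoxy, a longer chain such as butylsulfanyl, or a carboxylic acid at this position would stay within the scatter of compound 3 or move clearly away from it. The pair also speaks to only one dose by the oral route, so it leaves open whether compound 3 and compound 4 would remain indistinguishable at other doses, or whether the same exchange would behave alike on a core carrying a phenyl group.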